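Methylsulfanyl for nitro in a cytotoxicity screen

The source may hold more compounds than are shown below. What is called first, only, known or untested is meant among the compounds shown, and "the series" means these compounds.

Measured so far:
compound 1, `O=C(Nc1cccc([N+](=O)[O-])c1)C1CCCN(C(=O)c2cc(C(F)(F)F)cc(C(F)(F)F)c2)C1`, in an ADME assay on PC-3 cells (Homo sapiens) for cytotoxicity, read by WST assay, tested at 100 uM; on this read-out higher numbers stand for more inhibition at the one concentration tested (going by the name of the read-out) and lower numbers for less inhibition: 9%
compound 2, `O=C(Nc1cccc(Cc2ccccc2)c1)C1CCCN(C(=O)c2cccc(-c3ccco3)c2)C1`, in this assay: 0%
compound 3, `COCc1cccc(C(=O)N2CCCC(C(=O)Nc3ccc(Cl)cc3)C2)c1`, in this assay: 0%

All three compounds share the same core, and in this assay the three numbers sit close together: the value of compound 1 differs from those of compound 2 and compound 3 by amounts that are within the scatter, so none of them can be told apart from the others.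

Compound 4, `CSc1cccc(NC(=O)C2CCCN(C(=O)c3cc(C(F)(F)F)cc(C(F)(F)F)c3)C2)c1`, has not yet been measured. It differs from compound 1 in one place: methylsulfanyl in place of nitro on an aromatic carbon.

Among the measured compounds shown here, no pair of measured compounds differing in a single place is available, so the effect of this change has no precedent here. Since every measured compound sits near the bottom of the read-out, the step from compound 1 to compound 4 in this assay is expected to be no larger than the scatter, in either direction. Compound 4 is accordingly estimated to give 5%, within -8% to 20%, meaning an expected step of a number 4 percentage points lower from compound 1 to compound 4 (within the scatter).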

Compound 4, a percentage reported as inhibition, at one concentration (the size of the read-out at that concentration, not a potency): 0%
Compound 4: the middle estimate sits 5 percentage points above what was measured, and the stated range covers the measured number.
By their numbers in this assay, from the lowest: compounds 2, 3, 4 and 1 (each within the scatter of the next).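

In this assay, among the compounds shown here, the first comparison at a single place shows methylsulfanyl in place of nitro on this aromatic carbon giving a number 9 percentage points lower from compound 1 to compound 4 (within the scatter). The nitro group can thus be exchanged here, with the bis(trifluoromethyl)benzoyl side held constant, without a change that can be told from the scatter. Nothing available gives a reason for this result.

From the compounds shown here alone, whether an amine or a carboxylic acid on this aromatic carbon would give a step beyond the scatter remains open. So does whether this exchange would read the same with the other acyl groups on the shared core.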